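Cytotoxicity of a Sulfonamide in Place of an Amide

This account rests on a few compounds, and the source may have more. Where it says the series, first, only, none or still open, it means among the compounds named here.

Compound 1 `O=C(Nc1ncc(C(Oc2ccc3cc(Br)ccc3c2)c2ccc(Cl)cc2)s1)C1CCCO1`: "not toxic" (no number reported)
Compound 2 `Cc1ccc(C(=O)Nc2ncc(C(Oc3ccc4cc(Br)ccc4c3)c3ccc(Cl)cc3)s2)cc1`: "not toxic" (no number reported)
Compound 3 `N#Cc1cccc(C(=O)Nc2ncc(C(Oc3ccc4cc(Br)ccc4c3)c3ccc(Cl)cc3)s2)c1`: > 50000 nM

In an ADME assay on HepG2 2.2.15 cells (Homo sapiens) for cytotoxicity (a lower number here means that less compound is tolerated, a higher number that more compound is tolerated), compound 3 gives > 50000 nM, which is a limit of the assay rather than a number. Compound 1 and compound 2 are recorded only as not toxic, without a number. Among the three values shown, (the limit of > 50000 nM in this assay, at which 1 of the 3 values shown sits). Compound 4 `O=S(=O)(Nc1ncc(C(Oc2ccc3cc(Br)ccc3c2)c2ccc(Cl)cc2)s1)c1ccc2c(c1)CCO2` has not been measured in this assay. It differs from compound 3 in this way: a group of 12 heavy atoms (8 carbon, 3 oxygen, 1 sulfur; one five-membered non-aromatic ring with 1 hetero atom, one six-membered aromatic ring of carbon only) in place of a group of 10 heavy atoms (8 carbon, 1 nitrogen, 1 oxygen; one six-membered aromatic ring of carbon only), on a nitrogen on an aromatic ring. Going by the values given here, no step between measured compounds is known, so the expectation for compound 4 rests on the shared core, whose measured members all sit at or beyond the limit. The step that the limit leaves unreadable from compound 3 to compound 4 is expected to be none beyond the scatter. Compound 4 is estimated at 60000 nM, with a range from 25000 nM to 150000 nM.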

Compound 4, half-maximal cytotoxic concentration: > 50000 nM
Compound 4 was reported as a limit; the forecaster's own chance of this, stated with the estimate: 70%; the middle value lies beyond the limit too.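

Going by these compounds alone, compound 3 and compound 4 both stand at the limit of the assay rather than at a number, so no step between them can be read: the limit of > 50000 nM in this assay, at which 2 of the 4 values shown sit. The compounds shown leave open how much compound the cells tolerate in either case, and whether the exchanged group on the nitrogen changes it at all.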